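A few compounds are considered here, and "the series" means these few. Any claim that something is new, unique, unknown or untested is made for them only; others in the source may bear on it.

Of the compounds shown here, three built on the same core have been tested in an ADME assay on L929 cells (Mus musculus, culture collection number NCTC 929) for cytotoxicity, read by MTT assay, with a stated time of 72 h; on this read-out lower numbers stand for stronger inhibition and higher numbers for weaker inhibition. Compound 1 `CCCCCCCCc1c(O)cc(C)oc1=O` gives 145000 nM, compound 2 `CCCCCCCCCCCCCCCCc1c(O)cc(C)oc1=O` gives 38200 nM, and compound 3 `CCCCCCCCCCCCCCCC(=O)c1c(O)cc(C)oc1=O` gives 165000 nM. Going from compound 2 to compound 1 means (hydrogen in place of octyl on a saturated chain carbon, eight bonds along the chain from an aromatic carbon), and this step gave a 3.8-fold higher number from compound 2 to compound 1 (0.58 log units; beyond the scatter). How the core of compound 3 differs from that of compound 2 is not broken down here. Compound 4 `CCCCCCCC(=O)c1c(O)cc(C)oc1=O` has not yet been measured in this assay; it differs from compound 3 by hydrogen in place of octyl on a saturated chain carbon, seven bonds along the chain from a carbonyl carbon. For the measured compounds named here, this is the same kind of change as the one from compound 2 to compound 1, though the place differs in where the chain is counted from, seven bonds from a carbonyl carbon rather than eight bonds from an aromatic carbon. Because shortening the chain gave a 3.8-fold higher number from compound 2 to compound 1 (0.58 log units; beyond the scatter), a step of similar size, a 2.7-fold higher number from compound 3 to compound 4 (0.44 log units; beyond the scatter), is expected from compound 3 to compound 4. Compound 4 is therefore estimated at 450000 nM, between 180000 nM and 1200000 nM.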

Compound 4, half-maximal inhibitory concentration: 140000 nM
For compound 4 the middle estimate is 3.2-fold (0.51 log units) above the measured one; the whole stated range lies above it.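

In this assay, the new step is a 1.2-fold lower number from compound 3 to compound 4 (0.07 log units; within the scatter), so on the core of compound 3 this shortening of the chain leaves the number where it was. The same change therefore does not carry over as a fixed step from one core to the other: the same change on two cores in this assay, a 3.8-fold higher number (0.58 log units; beyond the scatter) from compound 2 to compound 1 and a 1.2-fold lower number (0.07 log units; within the scatter) from compound 3 to compound 4, 4.5-fold (0.65 log units) apart, beyond the scatter of two such steps. For the compounds shown here, with only one pair on each core, this shows that the outcome of the change depends on the core, but it does not show why, nor how the numbers would run at other chain lengths.

The compounds shown leave open what a dodecyl chain would give on either core. They also leave open whether an amine or a carboxylic acid in place of octyl would give a step of either size.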